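Chloro added to the amide of compound 3

The source may hold more compounds than are shown below. What is called first, only, known or untested is meant among the compounds shown, and "the series" means these compounds.

Measured so far:
compound 1, `O=C(Nc1cccc(-n2cc(-c3ccncc3)c(-c3ccc(Cl)c(O)c3)n2)c1)Nc1cccc(C(F)(F)F)c1`, > 32500 nM
compound 2, `COc1cc(-c2nn(-c3cccc(NC(=O)Nc4cc(C(F)(F)F)cc(C(F)(F)F)c4)c3)cc2-c2ccncc2)ccc1Cl`, 3710 nM
compound 3, `COc1cc(-c2nn(-c3cccc(NC(=O)c4cccc(C(F)(F)F)c4)c3)cc2-c2ccncc2)ccc1Cl`, > 50000 nM

Of the compounds shown here, three sharing one core have been tested in a functional assay on SK-MEL-2 cells (Homo sapiens) for inhibition, read by sulforhodamine B assay, with a stated time of 48 h; on this read-out higher numbers stand for lower toxicity in this test and lower numbers for higher toxicity in this test. Compound 2 gives 3710 nM and is the only one of the three with a measured number. For compound 1 the result is a limit of the assay, > 32500 nM, as noted in the limit of > 32500 nM in this assay, at which 1 of the 3 values shown sits. For compound 3 the result is likewise a limit, > 50000 nM, as noted in the limit of > 50000 nM in this assay, at which 1 of the 3 values shown sits. Going by the values given here, compound 3 therefore stands at the upper end of what this test reports, and no step between measured compounds is available to read a trend from.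

Compound 4, `COc1cc(-c2nn(-c3cccc(NC(=O)c4ccc(Cl)c(C(F)(F)F)c4)c3)cc2-c2ccncc2)ccc1Cl`, differs from compound 3 by chloro in place of hydrogen on an aromatic carbon; cut one bond further out, the change reads 3-(trifluoromethyl)phenyl to 4-chloro-3-(trifluoromethyl)phenyl. With compound 3 at a limit, any step from it can only be guessed; a modest move toward higher toxicity is expected, an at least 1.4-fold lower number from compound 3 to compound 4 (0.15 log units; that floor lies within the scatter), though a step not beyond the scatter is nearly as plausible. For compound 4 the expected value in this assay is 35000 nM, between 8000 nM and 100000 nM, with a real chance that only a limit is reported again.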

Compound 4, concentration lethal to 50% of the cells: > 32500 nM
Compound 4: only a limit was reported (the forecaster's own chance of this, stated with the estimate: 55%); the middle value lies beyond the limit too.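

Compound 4 gives > 32500 nM, which is a limit of the assay. Compound 3 gives > 50000 nM, also a limit, and no step can be read between compound 3 and compound 4. The compounds shown leave open whether chloro in place of hydrogen on the 3-(trifluoromethyl)phenyl group changes the result in this assay at all.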